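The compounds below may be only part of what the source reports. "The series", "measured", "known", "first", "only" and "open" are said of these compounds alone.

Measured in a functional assay on MCF7 cells (Homo sapiens) for inhibition, read by sulforhodamine B assay, with a stated time of 48 h; a lower number here means a stronger inhibitor of growth, a higher number a weaker inhibitor of growth:
- compound 1 `CCOC(=O)c1nn(-c2ccccc2)c(-c2ccc(OC)cc2)c1CNC(C)(C)C`: 116000 nM; 244000 nM (2 entries)
- compound 2 `CC(C)(C)NCc1c(C(=O)O)nn(-c2ccccc2)c1-c1ccccc1`: > 716000 nM (a limit)

Compound 2 has no number in this assay. Its entry, > 716000 nM, is a limit, and a further entry for it also gives no single number. Among the measured compounds shown here, compound 1 supplies the only numbers, 116000 nM; 244000 nM (2 entries).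

The next compound is compound 3 `COc1ccc(-c2c(CNC(C)(C)C)c(C(=O)O)nn2-c2ccccc2)cc1`. It follows from compound 2 by methoxy in place of hydrogen on an aromatic carbon, which is phenyl to 4-methoxyphenyl, with methoxy in place of hydrogen on an aromatic carbon. For the measured compounds named here, no measured step isolates this change, so the expectation rests on the position of compound 2, whose limit is > 716000 nM. No step beyond the scatter is expected, and the estimated step is an at least 1.1-fold lower number from compound 2 to compound 3 (0.04 log units; that floor lies within the scatter). The estimate for compound 3 is 650000 nM, with an expected range of 250000 nM to 1200000 nM.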

Compound 3, concentration for 50% growth inhibition: > 659000 nM
Compound 3 was reported as a limit; the forecaster's own chance of this, stated with the estimate: 65%; middle value at least 1.0-fold (0.00 log units) away from the limit.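

Among the compounds shown here, compound 2 and compound 3 both stand only as limits in this assay, so no step between them can be read for methoxy in place of hydrogen. As far as these compounds go, the size and even the direction of any effect of phenyl to 4-methoxyphenyl on growth inhibition remain open.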